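Thiophene-methylamines on a bicyclic core: cytotoxicity notes

The source may hold more compounds than are shown below. What is called first, only, known or untested is meant among the compounds shown, and "the series" means these compounds.

Measured so far:
compound 1 `CCc1csc(CN[C@@H]2C[C@H]3C[C@@H]([C@H]2C)C3(C)C)c1` — 25000 nM
compound 2 `Cc1ccsc1CN[C@@H]1C[C@H]2C[C@@H]([C@H]1C)C2(C)C` — 10000 nM
compound 3 `C[C@H]1[C@H](NCc2ccc(C(C)(C)C)s2)C[C@H]2C[C@@H]1C2(C)C` — 780 nM

All three were read in an ADME assay on MDCK cells (Canis lupus familiaris) for cytotoxicity, read by microscopy, with a stated time of 48 h; a lower number here means that less compound is tolerated, a higher number that more compound is tolerated. Compound 1 stands highest of the three numbers, so more of it is tolerated than of compound 2 and far more than of compound 3; both gaps lie beyond the scatter. Compound 4 `C[C@H]1[C@H](NCc2cc(C3CCCC3)cs2)C[C@H]2C[C@@H]1C2(C)C` is the next candidate. It differs from compound 1 by cyclopentyl in place of ethyl on an aromatic carbon. Among the measured compounds shown here, no step between measured compounds isolates this change, but the series runs downward as the group on the thiophene grows, because compound 3 gives 780 nM. A step of a 10-fold lower number from compound 1 to compound 4 (1.00 log units; beyond the scatter) is therefore expected, downward and beyond the scatter. Compound 4 is estimated at 2500 nM, within 600 nM to 9000 nM.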

Compound 4, minimum cytotoxic concentration: 1560 nM
For compound 4 the middle estimate is 1.6-fold (0.20 log units) above the measured one, and the stated range covers the measured number.
By their numbers in this assay, from the lowest: compounds 3 and 4 (each within the scatter of the next); then compound 2; then compound 1.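

Cyclopentyl in place of ethyl on this aromatic carbon, two ring bonds from the ring sulfur, gives a 16-fold lower number from compound 1 to compound 4 (1.20 log units; beyond the scatter) as the only step so far that isolates a single change. The position is therefore not indifferent to the group it carries, and a large step follows from exchanging an open two-carbon group for a carbocycle. Nothing available accounts for the size of this step. Going by these compounds, whether the ring itself or simply the larger group drives the step stays open. A cyclopropyl or a pentyl chain here would separate the two, and an amine on the cyclopentyl would test whether the ring tolerates substitution.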